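This account rests on a few compounds, and the source may have more. Where it says the series, first, only, none or still open, it means among the compounds named here.

Measured compounds:
compound 1 `O=C(N/N=C/c1cccc(O)c1O)c1ccc(-c2nc3ccccc3s2)cc1` gives 11200 nM
compound 2 `COc1cc(/C=N/NC(=O)c2ccc(-c3nc4ccccc4s3)cc2)cc(OC)c1` gives 16200 nM

Compound 2 holds the highest number of these two in an assay on isolated protein for inhibition of Maltase-glucoamylase (Homo sapiens), with a stated time of 15 min (a lower number here means a stronger inhibitor, a higher number a weaker inhibitor), and the nearest is compound 1, lower by a margin within the scatter. Compound 3 `O=C(N/N=C/c1ccc(F)c(Br)c1)c1ccc(-c2nc3ccccc3s2)cc1` differs from compound 2 in one place: 3-bromo-4-fluorophenyl in place of 3,5-dimethoxyphenyl on a carbon with a double bond to nitrogen. For the measured compounds named here, the only measured step that touches this position is the one from compound 1 to compound 2, a 1.4-fold higher number from compound 1 to compound 2 (0.16 log units; within the scatter), where a change of the aromatic ring on the carbon with a double bond to nitrogen left this assay essentially unchanged. Going by the values given here, no step involving a bromine or fluorine bearing ring is known. Given that the single comparable exchange stayed within the scatter, compound 3 is expected to show no step beyond the scatter, a 1.1-fold lower number from compound 2 to compound 3 (0.03 log units; within the scatter). The estimate for compound 3 is therefore 15000 nM, with a range from 6000 nM to 40000 nM.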

Compound 3, half-maximal inhibitory concentration: 28000 nM
Estimate against measurement, compound 3: 1.9-fold (0.27 log units) below; the measured number falls inside the stated range.
By their numbers in this assay, from the lowest: compounds 1, 2 and 3 (each within the scatter of the next, the first and the last beyond it).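

In this assay, for the compounds shown here, the ring on the carbon with a double bond to nitrogen now gives a first step beyond the scatter, though a modest one: a 2.5-fold higher number from compound 1 to compound 3 (0.40 log units; beyond the scatter), with 3-bromo-4-fluorophenyl in place of 2,3-dihydroxyphenyl. The exchange for 3,5-dimethoxyphenyl gives a 1.7-fold higher number from compound 2 to compound 3 (0.24 log units; within the scatter), so the dimethoxy compound is not separated from either of the other two, and only the two ends of this short series can be told apart. Nothing measured here accounts for the step.

The compounds shown leave open what an amine or a carboxylic acid on this ring, or a plain alkyl chain in its place, would do in this assay. Also open, going by these compounds, is what any single hydroxyl, methoxy, bromine or fluorine contributes on its own.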